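Oxime ether at the measured oxime: an expected small step

The compounds below may be only part of what the source reports. "The series", "measured", "known", "first", "only" and "open" are said of these compounds alone.

Compound 1 `COc1ccc([C@@H]2C/C(=N/OCc3cn(-c4ccc(O)cc4)nn3)c3cc(CC=C(C)C)c(OC)cc3O2)cc1`: 64%
Compound 2 `COc1ccc([C@@H]2C/C(=N/O)c3cc(CC=C(C)C)c(OC)cc3O2)cc1`: 45%
Compound 3 `COc1cc2c(cc1CC=C(C)C)C(=O)C[C@@H](c1ccc(Oc3ccc(F)cc3)cc1)O2`: 19%

In a functional assay on PC-3 cells (Homo sapiens) for inhibition, read by sulforhodamine B assay, with a stated time of 48 h, tested at 50 uM (a lower number here means less inhibition of growth, a higher number more inhibition of growth at the concentration tested), compound 2 gives 45%, the second highest of the three numbers. Compound 1 lies above it and compound 3 lies below it, and both gaps are beyond the scatter.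

The next compound to be tested is compound 4 `C#CCO/N=C1/C[C@@H](c2ccc(OC)cc2)Oc2cc(OC)c(CC=C(C)C)cc21`, which differs from compound 2 at one place: propargyl in place of hydrogen on an oxygen. In words, hydroxy becomes propargyloxy. Going by the values given here, no measured pair isolates a change of this kind, so the data offer only a weak guide. Compound 1 also carries a group in place of that hydrogen, and compound 1 gives 64%, but a single compound establishes no trend. A small rise is therefore expected, probably not beyond the scatter. The expected change is a number 5 percentage points higher from compound 2 to compound 4 (within the scatter). For compound 4 the estimated value is 50%, with an expected range of 32% to 68%.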

Compound 4, percent growth inhibition at one concentration: 41%
Compound 4: middle estimate off by 9 percentage points, on the high side; measured number inside the range.
By their numbers in this assay, from the lowest: compound 3; then compounds 4 and 2 (each within the scatter of the next); then compound 1.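

In this assay, the change from hydroxy to propargyloxy on the oxime oxygen gives a number 4 percentage points lower from compound 2 to compound 4 (within the scatter), so replacing this hydrogen with propargyl does not by itself shift growth inhibition beyond the scatter. The step with ethynyl in place of 1-(4-hydroxyphenyl)-1H-1,2,3-triazol-4-yl gives a number 23 percentage points lower from compound 1 to compound 4 (beyond the scatter), which shows that the group at the end of the chain on this oxygen can move the number beyond the scatter. No measured evidence here accounts for either step.

The compounds shown leave open whether the higher number belongs to the triazole itself or to its 4-hydroxyphenyl group. A triazole carrying a plain phenyl, or a carboxylic acid in place of that phenyl hydroxy, would separate these two parts.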